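From cyclopropyl to amino on a shared core

The compounds below may be only part of what the source reports. "The series", "measured", "known", "first", "only" and "open" are said of these compounds alone.

In a physicochemical assay for lipophilicity, using the shake flask method, in phosphate buffer, measured as octanol-water partition, at pH 7.4 (a higher number here means a more lipophilic compound, a lower number a more polar compound), compound 1 (`Cc1ncccc1-c1cnc(NCc2c(F)cc(C3CC3)c3c2CCO3)n2cnnc12`) is recorded as "not determined" (no result reported) and so offers no starting value. Compound 4 (`Cc1ncccc1-c1cnc(NCc2c(F)cc(N)c3c2CCO3)n2cnnc12`) has amino in place of cyclopropyl on an aromatic carbon and otherwise keeps the core of compound 1.

Two measured compounds carry other groups on that same aromatic carbon. In this assay compound 2 (`Cc1ncccc1-c1cnc(NCc2c(F)cc(O)c3c2CCO3)n2cnnc12`) gives 1.8 on the scale, and compound 3 (`COc1cc(F)c(CNc2ncc(-c3cccnc3C)c3nncn23)c2c1OCC2`) gives 2.3 on the same scale. Within the data shown here, the one measured step that bears on the question is a number 0.50 log units higher from compound 2 to compound 3 (beyond the scatter) and it is methyl in place of hydrogen on an oxygen on an aromatic ring. Among the measured compounds shown here, that step is not the change in question, and it shows only that one small exchange on this carbon has moved the reading by a modest amount. With no number for compound 1, no size or direction can be set for the step to compound 4, so compound 4 has to be placed by its measured neighbours instead.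

Amino keeps hydrogen on the atom that joins the ring, so the expectation leans towards compound 2 at 1.8 and not towards the methylated partner. For compound 4 a value of 1.8 is expected, with an estimated range from 1.4 to 2.2 in this measurement.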

Compound 4, distribution coefficient: 1.8
Estimate against measurement, compound 4: no gap at the digits printed, within the range that was stated.
By their numbers in this assay, from the lowest: compounds 2 and 4 (each within the scatter of the next); then compound 3.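

In this assay, amino in place of hydroxy on this aromatic carbon gives no change at the digits printed from compound 2 to compound 4 (within the scatter), whereas amino in place of methoxy gives a number 0.50 log units lower from compound 3 to compound 4 (beyond the scatter), which places compound 4 with compound 2 and apart from compound 3. The earlier compounds shown here showed only what a methyl on the oxygen does at this carbon; these steps add that exchanging the hydroxy oxygen for the nitrogen of an amino group leaves the reading in place on the shared core, at least for this one pair. No measurement available here accounts for either step, so the result stands as an observation without an explanation.

Going by these compounds, the steps that start from compound 1 cannot be read, so the place of cyclopropyl relative to amino, hydroxy and methoxy on this carbon stays open. Also open, on these data alone, is whether a methylamino or dimethylamino group would shift the reading as the methyl on the oxygen did in compound 3, and where a carboxylic acid on this same carbon would fall on the scale.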